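The source may report more compounds than this note shows. Statements on the series, on what has been measured and on what is new or still open speak of the compounds shown alone.

Measured so far:
- Compound 1 `NC(=O)c1cccc(-c2cc(C(O)(C(F)(F)F)C(F)(F)F)cnc2N2CCN(S(=O)(=O)c3ccc(N)nc3)CC2)c1`: 63 mL.min-1.g-1
- Compound 2 `Nc1ccc(S(=O)(=O)N2CCN(c3ncc(C(O)(C(F)(F)F)C(F)(F)F)cc3-c3cc4ccccc4[nH]3)CC2)cn1`: 146 mL.min-1.g-1

For the measured compounds named here, in an ADME assay (liver) for metabolic stability, with Liver microsome (Rattus norvegicus) as the target, using microsomes and NADPH, with a stated time of 30 min, tested at 1 uM (a higher number here means faster removal of the compound, a lower number slower removal), compound 2 gives 146 mL.min-1.g-1, the higher of the two numbers so far, which places it above its only neighbour, compound 1. The next compound to consider is compound 3 `Nc1ccc(S(=O)(=O)N2CCN(c3ncc(C(O)(C(F)(F)F)C(F)(F)F)cc3-c3cc4ccccc4s3)CC2)cn1`, which has not yet been measured. It carries 1-benzothiophen-2-yl in place of 1H-indol-2-yl on an aromatic carbon.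

Going by the values given here, only one measured step bears on this change. It is the modest step of a 2.3-fold higher number from compound 1 to compound 2 (0.37 log units; beyond the scatter), made at the same place when 1H-indol-2-yl replaced 3-carbamoylphenyl. That step swapped two quite different groups, so it is only a loose guide. Among the compounds with values here, no measured pair shows what happens when 1H-indol-2-yl gives way to 1-benzothiophen-2-yl. With so little evidence, only a small upward change is expected, one that would stay within the usual scatter. The expected size is a 1.2-fold higher number from compound 2 to compound 3 (0.07 log units; within the scatter). The estimate for compound 3 is 170 mL.min-1.g-1, with an expected range from 85 mL.min-1.g-1 to 330 mL.min-1.g-1.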

Compound 3, intrinsic clearance in microsomes: 315 mL.min-1.g-1
Compound 3: the middle estimate sits 1.9-fold (0.27 log units) below what was measured; low and high end bracket the measured number.
By their numbers in this assay, from the lowest: compound 1; then compound 2; then compound 3.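

In this assay, 1-benzothiophen-2-yl and 1H-indol-2-yl have the same ring types and differ in that sulfur replaces the ring nitrogen with its hydrogen, yet this exchange gives a 2.2-fold higher number from compound 2 to compound 3 (0.33 log units; beyond the scatter). The earlier step replaced 3-carbamoylphenyl with a quite different group, so it could not show that this position responds to so close an exchange; the new step shows that it does. The wider comparison gives a 5.0-fold higher number from compound 1 to compound 3 (0.70 log units; beyond the scatter), so among the three groups shown at this position, 3-carbamoylphenyl gives the slowest removal and 1-benzothiophen-2-yl the fastest.

The compounds shown offer no measurement that explains why the number rises with either exchange. They also leave open how the number would move with 1-benzofuran-2-yl, which has oxygen in the five-membered ring, or with an amine or a carboxylic acid on the 1-benzothiophen-2-yl group, and whether the same exchanges would give steps of similar size on a different core.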